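Swapping Iodine for a Thiophene Ring on a Nucleoside Core

This account rests on a few compounds, and the source may have more. Where it says the series, first, only, none or still open, it means among the compounds named here.

Compound 1 `Cc1ncnc2c1c(I)cn2[C@@H]1O[C@H](CO)[C@@H](O)[C@H]1O` is a sugar-bearing nucleoside whose core carries a methyl group and an iodo group. Among the compounds with values here, in a functional assay on HepG2 cells (Homo sapiens) for antiproliferative activity, read by XTT assay, with a stated time of 72 h (on this read-out higher numbers stand for weaker inhibition and lower numbers for stronger inhibition), compound 1 gives 3460 nM, the only plain number in this set. Compound 2 `Nc1nc2c(c(-c3ccco3)cn2[C@@H]2O[C@H](CO)[C@@H](O)[C@H]2O)c(=O)[nH]1` is a related nucleoside with a furan ring on its core; in this assay compound 2 reaches only the limit of > 20000 nM, and that value is a limit rather than a number. One of the two values sits at that limit (the limit of > 20000 nM in this assay, at which 1 of the 2 values shown sits). Compound 3 `Cc1ncnc2c1c(-c1cccs1)cn2[C@@H]1O[C@H](CO)[C@@H](O)[C@H]1O` has not yet been measured. It differs from compound 1 in one place: thiophen-2-yl in place of iodo on an aromatic carbon. Within the data shown here, no measured pair here shows a change of this kind, so the direction rests on the structures alone. The move from compound 1 to compound 3 is expected to make inhibition stronger, a 12-fold lower number from compound 1 to compound 3 (1.06 log units; beyond the scatter). Compound 3 is therefore estimated at 300 nM, within 50 nM to 3000 nM.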

Compound 3, half-maximal inhibitory concentration: > 15000 nM
Compound 3: no number, only a limit; the forecaster's own chance of this, stated with the estimate: 10%; middle value at least 50-fold (1.69 log units) from the limit.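

In this assay, putting thiophen-2-yl in place of iodo on this aromatic carbon weakens inhibition, with an at least 4.3-fold higher number from compound 1 to compound 3 (0.63 log units; beyond the scatter), a step beyond the usual scatter. Within the data shown here, this is the first direct evidence that the group at this position matters on this core, and the change runs towards weaker inhibition. Compound 3 gives only a limit of the assay and not a number, so the full size of the step stays unknown because of where compound 3 sits: the limit of > 15000 nM in this assay, at which 1 of the 3 values shown sits.

Going by these compounds, it remains open whether the loss belongs to the thiophene ring itself or would come with other replacements for iodo at this carbon. A chlorine atom, an amine or a phenyl ring at the same place on the core of compound 1 could begin to answer that.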